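From thiophen-2-yl to 1,3-thiazol-4-yl in liver microsomes

The source may hold more compounds than are shown below. What is called first, only, known or untested is meant among the compounds shown, and "the series" means these compounds.

Compound 1 (`O=C(NCc1ccc(Cl)cc1Cl)[C@@H]1CCC(=O)N1c1cccs1`) gives 1070 mL.min-1.g-1
Compound 2 (`O=C(NCc1ccc(Cl)cc1Cl)[C@@H]1CCC(=O)N1c1ccsc1`) gives 762 mL.min-1.g-1

Both numbers come from an ADME assay on microsomes from liver (Homo sapiens) for metabolic stability, read by HPLC, with a stated time of 60 min, tested at 0.2 mg/mL (a lower number here means slower removal, a higher number faster removal of the compound), and are the only ones available so far. Compound 1 stands level with compound 2 within the scatter, so the two cannot be ranked. Compound 3 (`O=C(NCc1ccc(Cl)cc1Cl)[C@@H]1CCC(=O)N1c1cscn1`) has not yet been measured. It keeps the core of compound 1 and exchanges one group (1,3-thiazol-4-yl in place of thiophen-2-yl on an amide-type nitrogen in a ring), with 1,3-thiazol-4-yl in place of thiophen-2-yl on an amide-type nitrogen in a ring. Among the compounds with values here, one measured step bears on this, the exchange of thiophen-2-yl for thiophen-3-yl at that same place (a 1.4-fold lower number from compound 1 to compound 2 (0.15 log units; within the scatter)). That exchange left the number within the scatter, which offers a guide to size. Neither measured compound carries 1,3-thiazol-4-yl, however, so the direction remains uncertain. The estimated step is a small move towards a lower number that is expected to stay within the scatter (a 1.4-fold lower number from compound 1 to compound 3 (0.15 log units; within the scatter)). In this assay the estimate for compound 3 is 750 mL.min-1.g-1 (range 350 mL.min-1.g-1 to 1300 mL.min-1.g-1).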

Compound 3, intrinsic clearance in microsomes: 379 mL.min-1.g-1
Compound 3: the middle estimate sits 2.0-fold (0.30 log units) above what was measured, within the range that was stated.
By their numbers in this assay, from the lowest: compounds 3, 2 and 1 (each within the scatter of the next, the first and the last beyond it).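

Placing 1,3-thiazol-4-yl on the amide-type nitrogen in a ring, in place of thiophen-2-yl, gives a 2.8-fold lower number from compound 1 to compound 3 (0.45 log units; beyond the scatter) in this assay, and this is the first step at this position to lie beyond the scatter. Set against the other thiophen, the same group gives a 2.0-fold lower number from compound 2 to compound 3 (0.30 log units; within the scatter), so the new ring is clearly separated from only one of the two thiophens. The position can therefore shift the number measurably, even though the entering ring, like the one that leaves, is a five-membered aromatic ring with 5 heavy atoms; the exchange differs in having 2 hetero atoms rather than 1, but three compounds cannot show that this difference is what matters.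

No measurement shown here explains why the number is lower for the thiazole than for thiophen-2-yl. Also open, going by these compounds, is how this assay would respond to a pyridine ring at this place, or to a thiazole carrying a methyl group or an amine.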